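The source may report more compounds than this note shows. Statements on the series, on what has been measured and on what is new or still open speak of the compounds shown alone.

Compound 3 `O=C(C/C=C/c1ccccc1)Nc1nc2ccccc2c(=O)s1` gives the highest number of the three measured compounds in an assay on membranes from brain for displacement of a labelled ligand from adenosine receptor A1 (Rattus norvegicus), read by scintillation counting, with a stated time of 90 min (a lower number here means a stronger inhibitor, a higher number a weaker inhibitor), at 53 nM. Its nearest neighbour is compound 2 `O=C(C/C=C/c1cccc(Cl)c1)Nc1nc2ccccc2c(=O)s1`, which gives 11.4 nM, and the furthest is compound 1 `COc1cccc(/C=C/CC(=O)Nc2nc3ccccc3c(=O)s2)c1`, which gives 11.2 nM. Compound 4 `O=C(C/C=C/c1ccc(Cl)c(Cl)c1)Nc1nc2ccccc2c(=O)s1` has not yet been measured; it differs from compound 3 in one place: 3,4-dichlorophenyl in place of phenyl on a double-bonded chain carbon bound to a double-bonded chain carbon. Two of the measured steps bear directly on this change. The step of a 4.6-fold higher number from compound 2 to compound 3 (0.67 log units; beyond the scatter) shows that taking away a chloro on the aromatic carbon raised the number, and the step of a 4.7-fold higher number from compound 1 to compound 3 (0.68 log units; beyond the scatter) shows a similar rise for taking away a methoxy, while the step of a 1.0-fold higher number from compound 1 to compound 2 (0.01 log units; within the scatter) shows the two substituents giving numbers that are indistinguishable. A single chloro on the ring thus lowered the number modestly, and compound 4 carries two. The expected step in this assay is therefore a modest fall, a 6.6-fold lower number from compound 3 to compound 4 (0.82 log units; beyond the scatter), of roughly the size seen for compound 2 or somewhat larger. The estimate for compound 4 is 8 nM, expected to fall between 3 nM and 25 nM.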

Compound 4, inhibition constant: >= 1500 nM
Compound 4: only a limit was reported; the forecaster's own chance of this, stated with the estimate: 2%; middle value at least 180-fold (2.27 log units) from the limit.
By their numbers in this assay, from the lowest: compounds 1 and 2 (each within the scatter of the next); then compound 3. At a limit, above all of these: compound 4.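

In this assay, for the compounds shown here, a further substituent on the ring does not continue the earlier trend: the change to 3,4-dichlorophenyl gives an at least 28-fold higher number from compound 3 to compound 4 (1.45 log units; beyond the scatter), the opposite direction from the single chloro of compound 2 and the single methoxy of compound 1, which both give lower numbers than compound 3. One more chloro in place of hydrogen on an aromatic carbon gives an at least 130-fold higher number from compound 2 to compound 4 (2.11 log units; beyond the scatter), and 3,4-dichlorophenyl in place of 3-methoxyphenyl gives an at least 130-fold higher number from compound 1 to compound 4 (2.12 log units; beyond the scatter). The value of compound 4 is a limit, and all three steps are read from it: the limit of >= 1500 nM in this assay, at which 1 of the 4 values shown sits.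

On these data alone, how far the true number lies past that limit remains open. As far as these compounds go, it is also open whether a second methoxy, a fluoro, a methyl or an amine on the ring would raise the number in the same way.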